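A Chloro for a Methyl on the Carbonyl-Bearing Ring

This account rests on a few compounds, and the source may have more. Where it says the series, first, only, none or still open, it means among the compounds named here.

Measured so far, in a functional assay on PC-3 cells (Homo sapiens) for cytotoxicity, read by MTT assay, with a stated time of 48 h; a higher number here means a weaker inhibitor, a lower number a stronger inhibitor:
compound 1 `COc1cc(-c2nnc3n2NC(c2ccco2)C(C(=O)c2cccs2)S3)cc(OC)c1OC` gives 46200 nM;
compound 2 `COc1cc(-c2nnc3n2NC(c2cccs2)C(C(=O)c2ccc(C)cc2)S3)cc(OC)c1OC` gives 5090 nM;
compound 3 `COc1cc(-c2nnc3n2NC(c2ccco2)C(C(=O)c2ccc(C)cc2)S3)cc(OC)c1OC` gives 7500 nM.

Compound 2 holds the lowest of the three numbers in this assay. Its nearest neighbour is compound 3, and the two differ only by furan-2-yl in place of thiophen-2-yl on a saturated ring carbon, a change that reads a 1.5-fold higher number from compound 2 to compound 3 (0.17 log units; within the scatter). Going by the values given here, compound 1 sits furthest away; the change from compound 1 to compound 3, 4-methylphenyl in place of thiophen-2-yl on a carbonyl carbon, reads a 6.2-fold lower number from compound 1 to compound 3 (0.79 log units; beyond the scatter), the only step here that touches the carbonyl-bearing ring.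

Compound 4 `COc1cc(-c2nnc3n2NC(c2cccs2)C(C(=O)c2ccc(Cl)cc2)S3)cc(OC)c1OC` is the next step from compound 2: chloro in place of methyl on an aromatic carbon. Among the compounds with values here, no measured pair shows a substituent swap on that six-membered ring, so the nearest guide is the modest sensitivity of this assay to what sits on the carbonyl carbon, seen from compound 1 to compound 3. The step from compound 2 to compound 4 is therefore expected to be small, about a 1.1-fold lower number from compound 2 to compound 4 (0.05 log units; within the scatter), with no clear direction. Compound 4 is estimated at 4500 nM, within a range from 1800 nM to 12000 nM.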

Compound 4, half-maximal inhibitory concentration: 32500 nM
Compound 4: middle estimate off by 7.2-fold (0.86 log units), on the low side, outside the stated range (above it).
By their numbers in this assay, from the lowest: compounds 2 and 3 (each within the scatter of the next); then compounds 4 and 1 (each within the scatter of the next).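

Chloro in place of methyl, a swap of a single heavy atom para to a large group, reads a 6.4-fold higher number from compound 2 to compound 4 (0.81 log units; beyond the scatter) in this assay and so is not the silent change that the earlier compounds left room for. Going by these compounds alone, until now, the only step touching the carbonyl-bearing ring was the exchange of a whole ring, a 6.2-fold lower number from compound 1 to compound 3 (0.79 log units; beyond the scatter); this result shows that the number also responds to one substituent on the six-membered ring. Nothing available here accounts for the size of this step.

The compounds shown leave open whether this is particular to chloro or to the loss of methyl, and how a fluoro, a methoxy or an amine at this place would read. On these data alone, it also remains open whether the same swap reads alike with the furan-2-yl group of compound 3 on the saturated ring carbon.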